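The source may report more compounds than this note shows. Statements on the series, on what has been measured and on what is new or still open speak of the compounds shown alone.

The measured compounds:

- compound 1, `CC(C)N(Cc1cccc(OCCCCCC(=O)O)c1)C(=O)c1ccc(-c2cccc(-c3ccccc3)c2)cc1`; in an ADME assay on BJ cells (Homo sapiens) for cytotoxicity, read by CellTiter-Glo and resazurin assay, with a stated time of 72 h (a lower number here means that less compound is needed, a higher number that more compound is needed for the effect), compound 1 gives > 26000 nM, a limit of the assay rather than a number.
- compound 2, `CCOC(=O)CCCCCOc1cccc(CN(C(=O)c2ccc(-c3cccc(-c4ccccc4)c3)cc2)C(C)C)c1`; compound 2 gives > 26000 nM, again a limit and not a number.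
- compound 3, `CCOC(=O)CCCCCOc1cccc(CN(C(=O)c2ccc(-c3cccc(Oc4ccccc4)c3)cc2)C(C)C)c1`; compound 3 gives > 19600 nM, also a limit.

Compound 2 therefore stands at the limit of > 26000 nM in this assay, at which 2 of the 3 values shown sit, and nothing more exact is known about it. The two measured steps, a step that the two limits leave unreadable from compound 1 to compound 2 and a step that the two limits leave unreadable from compound 2 to compound 3, cannot be read in size because each end sits at a limit, one of them at the limit of > 19600 nM in this assay, at which 1 of the 3 values shown sits.

Compound 4 is `CCOC(=O)CCCCCOc1cccc(CN(C(=O)c2ccc(-c3ccc(C(C)=O)s3)cc2)C(C)C)c1`. It differs from compound 2 in one place: 5-acetylthiophen-2-yl in place of 3-phenylphenyl on an aromatic carbon. Neither measured step bears on this kind of change, and neither gives a readable size at all, so no direction beyond the scatter can be argued from them. Going by the values given here, the only guide is that all three measured compounds sit at limits in this assay, which suggests compound 4 may do the same.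

Compound 4 is therefore estimated at 26000 nM, in a range from 8000 nM to 60000 nM. The step this estimate means is a number no higher from compound 2 to compound 4 (the limit leaves the size open), an expectation only.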

Compound 4, half-maximal effective concentration: > 26000 nM
Compound 4 gave a limit, no number; the forecaster's own chance of this, stated with the estimate: 75%; the middle value lies on the limit itself.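

In this assay compound 4 gives > 26000 nM, a limit of the assay and not a number. Compound 2 also stands at a limit, so no step can be read between compound 2 and compound 4. The compounds shown leave open whether 5-acetylthiophen-2-yl in place of 3-phenylphenyl changes the concentration needed for the effect at all.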